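A few compounds are considered here, and "the series" means these few. Any claim that something is new, unique, unknown or untested is made for them only; others in the source may bear on it.

Compound 1, `CCCCCCCCCCCOc1ccccc1CCC(=O)OC[C@H]1OCCC[C@H]1OP(=O)(O)OC[C@H](N)C(=O)O`: 5.2% in an assay on HEK293-A cells for agonist activity at probable G-protein coupled receptor 34 (Mus musculus), with a stated time of 1.5 h; on this read-out higher numbers stand for larger maximal responses and lower numbers for smaller maximal responses
Compound 2, `N[C@@H](COP(=O)(O)OC[C@H]1OCC=C[C@H]1OC(=O)CCc1ccccc1OCc1cccc(Oc2ccccc2)c1)C(=O)O`: 16.5%
Compound 3, `CCCCCCCC/C=C\CCCCCCCC(=O)O[C@H]1CCCO[C@@H]1COP(=O)(O)OC[C@H](N)C(=O)O`: "not active" (no number reported)

Of the two numbers reported, compound 2 gives the higher one; compound 1 lies below it by a gap beyond the usual scatter, and compound 3 is reported without a number. Compound 4, `N[C@@H](COP(=O)(O)OC[C@H]1OCC=C[C@@H]1OC(=O)CCc1ccccc1OCc1cccc(Oc2ccccc2)c1)C(=O)O`, has not yet been measured. It differs from compound 2 as follows: the two compounds have the same atoms and bonds; at least one stereo element is drawn with a configuration in one of them and without one in the other: 1 of 4 stereo elements differ; a stereocentre at a saturated ring carbon is drawn R in compound 2 and S in compound 4. Within the data shown here, no step between two measured compounds involves this kind of change, so nothing shows how large its effect tends to be. Such a change could leave the maximal response near that of compound 2 or reduce it. The expected step of a number 6.5 percentage points lower from compound 2 to compound 4 (within the scatter) is a modest decrease, roughly the size of the scatter. Compound 4 is therefore estimated at 10%, within a range from 0% to 25%.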

Compound 4, largest response reached (Emax), in percent of the reference or control that the assay uses: "not active" (no number reported)
The entry for compound 4 holds no number; there is nothing to compare the estimate with.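

Among these compounds, compound 4 is reported as not active, without a number, and no step from compound 2 to compound 4 can be read. The compounds shown leave open how large a change in maximal response this single stereocentre causes in this assay.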